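This account rests on a few compounds, and the source may have more. Where it says the series, first, only, none or still open, it means among the compounds named here.

Measured so far in a functional assay on FM3A/O cells (Mus musculus) for inhibition; on this read-out lower numbers stand for stronger inhibition and higher numbers for weaker inhibition:

compound 1, `O=c1[nH]c(=O)n([C@H]2C[C@H](O)[C@@H](CO)O2)cc1C#CI`, 300 nM
compound 2, `C[Si](C)(C)C#Cc1cn([C@H]2C[C@H](O)[C@@H](CO)O2)c(=O)[nH]c1=O`, 230 nM

Compound 2 gives the lower of the two numbers in this assay, its nearest neighbour being compound 1; the step of a 1.3-fold lower number from compound 1 to compound 2 (0.12 log units; within the scatter) is within the scatter, so the two compounds cannot be told apart on these data.

Compound 3, `C[Si](C)(C)C#Cc1cn([C@@H]2O[C@H](CO)[C@@H](O)[C@@H]2O)c(=O)[nH]c1=O`, is not yet measured. It differs from compound 2 in one place: hydroxy in place of hydrogen on a saturated ring carbon. Going by the values given here, the only measured step, a 1.3-fold lower number from compound 1 to compound 2 (0.12 log units; within the scatter), concerns the group on the triple-bonded carbon and leaves the five-membered ring untouched, so no measured step bears on a hydroxy in place of hydrogen on a saturated ring carbon. There is no basis in the series for the size or direction of this change, and the estimate therefore carries a wide range.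

The number for compound 3 in this assay is expected to come out higher than that of compound 2, a step of a 13-fold higher number from compound 2 to compound 3 (1.12 log units; beyond the scatter). Compound 3 is estimated at 3000 nM, with a range from 500 nM to 30000 nM.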

Compound 3, half-maximal inhibitory concentration: >= 250000 nM
Compound 3: a limit, no number; the forecaster's own chance of this, stated with the estimate: 25%; at least 83-fold (1.92 log units) between middle value and limit.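

Working notes on the series. Compound 3 stays at a limit of the assay, with no number, in this assay: the limit of >= 250000 nM in this assay, at which 1 of the 3 values shown sits.

On a saturated ring carbon of the five-membered ring, next to the ring atom that bears a large group, hydroxy in place of hydrogen gives an at least 1000-fold higher number from compound 2 to compound 3 (3.03 log units; beyond the scatter). This is the only step shown that lies beyond the scatter, whereas the change at the triple-bonded carbon, a 1.3-fold lower number from compound 1 to compound 2 (0.12 log units; within the scatter), could not separate its two compounds, so on these compounds the saturated ring carbon is the place where a single change moves the read-out strongly and in the direction of weaker inhibition.

The true size of the step stays open, since one end of it is a limit, and the compounds shown do not tell whether the loss belongs to hydroxy alone or would also follow from fluorine, a methoxy group or an amine on the same carbon. Also open, from the compounds shown here alone, is whether the iodine-bearing group on the triple-bonded carbon would behave the same way with hydroxy on this ring carbon.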